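The compounds below may be only part of what the source reports. "The series", "measured", "known", "first", "only" and "open" are said of these compounds alone.

Series notes, step from compound 2 to compound 3.

Compound 1 `Cn1c(COc2cccc(C(=O)O)c2)nc2ccc(Oc3cccc(Cl)n3)cc21` and compound 2 `Cn1c(COc2cccc(C(=O)O)c2)nc2ccc(Oc3ncccc3Cl)cc21` share one core and differ only in the chloropyridinyl group on the aryl oxygen. In an ADME assay for permeability, using PAMPA, with a stated time of 4 h (on this read-out lower numbers stand for lower permeability and higher numbers for higher permeability), compound 1 gives 7.6 10^-6 cm/s. In this assay compound 2 gives 8.1 10^-6 cm/s, the higher of the two numbers, though the step of a 1.1-fold higher number from compound 1 to compound 2 (0.03 log units; within the scatter) is too small to separate the pair.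

Compound 3 `Cc1ccnc(Oc2ccc3nc(COc4cccc(C(=O)O)c4)n(C)c3c2)c1` is the next member. Relative to compound 2 the change is 4-methylpyridin-2-yl in place of 3-chloropyridin-2-yl on an oxygen on an aromatic ring. Going by the values given here, the only measured step, a 1.1-fold higher number from compound 1 to compound 2 (0.03 log units; within the scatter), also moves a substituent on the same pyridinyl ring and leaves the read-out unchanged within scatter; no measured step exchanges a chlorine for a methyl, so that part of the change has no precedent here. On this basis no shift beyond the scatter is expected in this assay, in either direction. For compound 3 the expected result in this assay is 8 10^-6 cm/s, with a range of 4 10^-6 cm/s to 16 10^-6 cm/s, meaning an expected step of a 1.0-fold lower number from compound 2 to compound 3 (0.01 log units; within the scatter) from compound 2, which rests on compound 2 at 8.1 10^-6 cm/s.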

Compound 3, apparent permeability: 3.5 10^-6 cm/s
Compound 3: the middle estimate sits 2.3-fold (0.36 log units) above what was measured; the measured number lies below the stated range.
By their numbers in this assay, from the lowest: compound 3; then compounds 1 and 2 (each within the scatter of the next).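

In this assay, the group on an oxygen on an aromatic ring now proves able to move the read-out: there is a 2.3-fold lower number from compound 2 to compound 3 (0.36 log units; beyond the scatter) and a 2.2-fold lower number from compound 1 to compound 3 (0.34 log units; beyond the scatter), whereas a 1.1-fold higher number from compound 1 to compound 2 (0.03 log units; within the scatter) had shown no separation between the two chloropyridinyl groups. Compound 1 and compound 2 therefore stand together with compound 3 below both, so exchanging the chlorine-bearing ring for 4-methylpyridin-2-yl registers where the earlier chlorine-to-chlorine comparison did not, even though the groups match in heavy-atom count, hydrogen-bond donors, hydrogen-bond acceptors and net charge. No accompanying measurement bears on the origin of this step.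

The compounds shown leave open whether the lower number goes with the loss of chlorine, the arrival of methyl or the different placement of the substituent, since all of these change together in this single exchange. A pyridinyl ring carrying neither chlorine nor methyl, or one carrying a methoxy group or an amine, would help to separate these readings.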